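A few compounds are considered here, and "the series" means these few. Any claim that something is new, unique, unknown or untested is made for them only; others in the source may bear on it.

The first assay, an assay on RPMI-8226 cells for antagonist activity at P2X purinoceptor 7 (Homo sapiens), read by calcium flux (a lower number here means a stronger inhibitor, a higher number a weaker inhibitor), brings together two measured compounds. Compound 1, `O=c1[nH]c2ccccc2n1CCCN1CCN(S(=O)(=O)c2ccc([N+](=O)[O-])cc2)CC1`, gives in this assay only a limit, > 10000 nM, and not a number. Within the data shown here, compound 2, `O=c1[nH]c2ccccc2n1CCCCCN1CCN(C(c2ccccc2)c2ccccc2)CC1`, gives 560 nM in this assay, the only number measured. Beside it the result for compound 1 stands as a limit, (the limit of > 10000 nM in this assay, at which 1 of the 2 values shown sits). Compound 3, `Cc1cc2ncn(CCCCN3CCN(C(c4ccccc4)c4ccccc4)CC3)c2cc1C`, is not yet measured. It differs from compound 2 in one place: a group of 11 heavy atoms (9 carbon, 2 nitrogen; one five-membered aromatic ring with 2 hetero atoms, one six-membered aromatic ring of carbon only) in place of a group of 11 heavy atoms (8 carbon, 2 nitrogen, 1 oxygen; one five-membered aromatic ring with 2 hetero atoms, one six-membered aromatic ring of carbon only), on a saturated chain carbon, four bonds along the chain from an amine nitrogen in a ring. Among the measured compounds shown here, no step between two measured compounds is available to gauge this change, so the expectation rests on compound 2 alone, with the change treated as a modest one. The step from compound 2 to compound 3 in this assay is expected to be a 1.4-fold higher number from compound 2 to compound 3 (0.15 log units; within the scatter), a shift that may not rise beyond the usual scatter. Compound 3 is estimated at 800 nM in this assay, within a range from 250 nM to 3000 nM.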

Compound 3, half-maximal inhibitory concentration: 770 nM
For compound 3 the middle estimate is 1.0-fold (0.02 log units) above the measured one, within the range that was stated.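

In this assay, putting 5,6-dimethyl-1H-benzimidazol-1-yl on this saturated chain carbon gives a 1.4-fold higher number from compound 2 to compound 3 (0.14 log units; within the scatter). Among these compounds, this is the first comparison of two measured compounds, and it shows that a group with 0 hydrogen-bond donors can take the place of one with 1 hydrogen-bond donor and a double bond outside the aromatic rings without a shift beyond the usual scatter, so neither feature of the departing group is needed for activity of this size. Nothing measured here offers a reason for this result.

The compounds shown leave open whether this tolerance extends to groups that differ more, such as a benzimidazole carrying an amine or a carboxylic acid. They also leave open what a longer chain would do at this position.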